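Swapping the aryl group on the pyridazinone nitrogen

The source may hold more compounds than are shown below. What is called first, only, known or untested is meant among the compounds shown, and "the series" means these compounds.

Compound 3 `Cn1ccc2c(Oc3ccc(NC(=O)c4nn(-c5ccc(Br)cc5F)ccc4=O)cc3)ccnc21` gives 19800 nM in a functional assay on MCF7 cells (Homo sapiens) for cytotoxicity, read by MTT assay, with a stated time of 72 h; on this read-out higher numbers stand for weaker inhibition and lower numbers for stronger inhibition. That is the second highest of three numbers: compound 2 `Cn1ccc2c(Oc3ccc(NC(=O)c4nn(-c5ccccc5)ccc4=O)cc3)ccnc21` gives 45200 nM, while compound 1 `O=C(Nc1ccc(Oc2ccnc3[nH]ccc23)cc1)c1nn(-c2ccc(Cl)c(C(F)(F)F)c2)ccc1=O` gives 6270 nM. Compound 4 `Cn1ccc2c(Oc3ccc(NC(=O)c4nn(-c5ccc(Cl)c(C(F)(F)F)c5)ccc4=O)cc3)ccnc21` differs from compound 3 by one change, (4-chloro-3-(trifluoromethyl)phenyl in place of 4-bromo-2-fluorophenyl on an aromatic nitrogen). Among the compounds with values here, one measured step bears on this kind of change: a 2.3-fold lower number from compound 2 to compound 3 (0.36 log units; beyond the scatter), a move from an unsubstituted ring to a halogenated one. Compound 1 carries the same 4-chloro-3-(trifluoromethyl)phenyl group as compound 4 on a different core, and its number is the lowest of the three. A lower number is therefore expected for compound 4, and the step of a 2.2-fold lower number from compound 3 to compound 4 (0.34 log units; beyond the scatter) is the estimate. Compound 4 is expected at about 9000 nM, within 3500 nM to 25000 nM.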

Compound 4, half-maximal inhibitory concentration: 15200 nM
Compound 4: the middle estimate sits 1.7-fold (0.23 log units) below what was measured; low and high end bracket the measured number.
By their numbers in this assay, from the lowest: compound 1; then compounds 4 and 3 (each within the scatter of the next); then compound 2.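

In this assay, replacing 4-bromo-2-fluorophenyl with 4-chloro-3-(trifluoromethyl)phenyl gives a 1.3-fold lower number from compound 3 to compound 4 (0.11 log units; within the scatter), so these two substituted rings cannot be told apart here, yet a 3.0-fold lower number from compound 2 to compound 4 (0.47 log units; beyond the scatter) separates the new ring from plain phenyl. With that ring kept, methyl in place of hydrogen on an aromatic nitrogen gives a 2.4-fold higher number from compound 1 to compound 4 (0.38 log units; beyond the scatter) and so matters at least as much as the last ring swap. No measurement here accounts for these differences.

On these data alone, it remains open whether chloro or trifluoromethyl alone would give the same number. A phenyl ring carrying an amine or a carboxylic acid is also untested among these compounds.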